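Swapping the Aryl Substituent: Predicting Compound 4

The compounds below may be only part of what the source reports. "The series", "measured", "known", "first", "only" and "open" are said of these compounds alone.

Three compounds sharing one core were measured in an in vitro assay on HEK385-7 cells for displacement of a labelled ligand from prostaglandin D2 receptor 2 (Homo sapiens); on this read-out higher numbers stand for weaker inhibition and lower numbers for stronger inhibition. Compound 1 `O=C(O)Cc1sc(C(c2ccc(F)cc2)c2ccc(F)cc2)nc1-c1ccnc(N2CCCC2)c1` gives 230 nM, and compound 2 `NS(=O)(=O)c1cccc(-c2nc(C(c3ccc(F)cc3)c3ccc(F)cc3)sc2CC(=O)O)c1` gives 140 nM; the two differ by a 1.6-fold lower number from compound 1 to compound 2 (0.22 log units; within the scatter). Compound 3 `Cc1cc(-c2nc(C(c3ccc(F)cc3)c3ccc(F)cc3)sc2CC(=O)O)cnc1N` gives 880 nM, the highest of the three numbers, with steps of a 3.8-fold higher number from compound 1 to compound 3 (0.58 log units; beyond the scatter) and a 6.3-fold higher number from compound 2 to compound 3 (0.80 log units; beyond the scatter) setting it apart from the others beyond the scatter.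

Compound 4 `O=C(O)Cc1sc(C(c2ccc(F)cc2)c2ccc(F)cc2)nc1-c1ccnc(O)c1` is the next compound to be measured. It differs from compound 3 at the aromatic carbon that carries the aryl group:

2-hydroxypyridin-4-yl in place of 6-amino-5-methylpyridin-3-yl on an aromatic carbon

Both measured steps into compound 3 bear on this position, and both were modest but beyond the scatter, so a change at this carbon can move the number noticeably. Compound 4 carries its hydroxyl group on a pyridin-4-yl ring, the same ring attachment seen in compound 1, whereas compound 3 carries a pyridin-3-yl ring. Going by the values given here, an estimated step of a 2.2-fold lower number from compound 3 to compound 4 (0.34 log units; beyond the scatter) is therefore expected, toward the value of compound 1 rather than away from it, though the hydroxyl group has no direct precedent among the measured compounds. Compound 4 is expected to give about 400 nM in this assay, with a likely range from 150 nM to 1100 nM.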

Compound 4, half-maximal inhibitory concentration: 68 nM
Compound 4: the middle estimate sits 5.9-fold (0.77 log units) above what was measured; the measured number lies below the stated range.
By their numbers in this assay, from the lowest: compound 4; then compounds 2 and 1 (each within the scatter of the next); then compound 3.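

The step of a 13-fold lower number from compound 3 to compound 4 (1.11 log units; beyond the scatter) is the largest seen at this aromatic carbon in this assay, and it shows that a change of aryl group here can move the number much further than the earlier compounds had shown. Compound 4 also goes beyond the two best earlier compounds, with a 2.1-fold lower number from compound 2 to compound 4 (0.31 log units; beyond the scatter) and a 3.4-fold lower number from compound 1 to compound 4 (0.53 log units; beyond the scatter), so it is now the most potent of the four, its steps to all the others being beyond the scatter. The last of these steps keeps the pyridin-4-yl ring and exchanges only pyrrolidin-1-yl for hydroxy, which shows that the substituent on that ring matters on its own and not only the ring attachment.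

No measured property of these compounds bears on the result, so the reason for these differences stays unknown. The compounds shown leave open whether a methoxy group or an amine in place of the hydroxy on the pyridin-4-yl ring would keep a number like that of compound 4, and whether a hydroxy group on a pyridin-3-yl ring would do the same.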